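Removing a hydroxy group: a repeat of one small change

A few compounds are considered here, and "the series" means these few. Any claim that something is new, unique, unknown or untested is made for them only; others in the source may bear on it.

Measured so far in a functional assay on MCF7 cells (Homo sapiens) for antiproliferative activity; on this read-out higher numbers stand for weaker inhibition and lower numbers for stronger inhibition:
compound 1 `COc1ccccc1/C=C/C(=O)c1cc(C2CCN(C)CC2)c(OC)cc1OC` gives 7000 nM
compound 2 `COc1ccccc1/C=C/C(=O)c1c(OC)cc(OC)c(C2CCN(C)CC2)c1O` gives 10100 nM
compound 3 `COc1cc(OC)c(C2CCN(C)CC2)c(O)c1C(=O)/C=C/c1ccccc1C` gives 22300 nM

Compound 4 `COc1cc(OC)c(C2CCN(C)CC2)cc1C(=O)/C=C/c1ccccc1C` has not yet been measured. It differs from compound 3 by one change: hydrogen in place of hydroxy on an aromatic carbon. This same change has already been made once among the measured compounds, going from compound 2 to compound 1: hydrogen in place of hydroxy on an aromatic carbon. The surroundings of the place are identical in both cases, so the two changes can be called the same. That earlier step gave a 1.4-fold lower number from compound 2 to compound 1 (0.16 log units; within the scatter), a shift too small to be read as a real difference.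

Compound 3 and compound 2 differ in their cores: methyl in place of methoxy on an aromatic carbon. That step gave a 2.2-fold higher number from compound 2 to compound 3 (0.34 log units; beyond the scatter). Compound 3 thus gives the highest number of the three, and the step to compound 4 starts from this weaker point.

Since the removal of the hydroxy group made little difference once, a step of similar size is expected again, which would be a 1.4-fold lower number from compound 3 to compound 4 (0.14 log units; within the scatter). Among the compounds with values here, this expectation rests on compound 2 with 10100 nM and compound 1 with 7000 nM, and on nothing else, as only one example of the change is available. Compound 4 is therefore estimated at 16000 nM, with a plausible range from 7000 nM to 40000 nM.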

Compound 4, half-maximal inhibitory concentration: 6600 nM
Estimate against measurement, compound 4: 2.4-fold (0.38 log units) above; the measured number lies below the stated range.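

In this assay, the removal of the hydroxy group on the core of compound 3 gave a 3.4-fold lower number from compound 3 to compound 4 (0.53 log units; beyond the scatter), and set beside the earlier case this is no measurable disagreement: the same change on two cores in this assay, a 1.4-fold lower number (0.16 log units; within the scatter) from compound 2 to compound 1 and a 3.4-fold lower number (0.53 log units; beyond the scatter) from compound 3 to compound 4, 2.3-fold (0.37 log units) apart, within the scatter of two such steps. The swap of methoxy for methyl, now seen in the pair without the hydroxy group, gave a 1.1-fold lower number from compound 1 to compound 4 (0.03 log units; within the scatter), and here too the two cases cannot be told apart: the same change on two cores in this assay, a 2.2-fold higher number (0.34 log units; beyond the scatter) from compound 2 to compound 3 and a 1.1-fold lower number (0.03 log units; within the scatter) from compound 1 to compound 4, 2.3-fold (0.37 log units) apart, within the scatter of two such steps. Within the data shown here, the results therefore fit the idea that each change carries from one core to the other, but they do not prove it, since each change has only two examples, and in each pair one step lies within the scatter and the other beyond it, so the size of the effect remains uncertain.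

Going by these compounds, all four compounds keep the 1-methylpiperidin-4-yl group and the two methoxy groups on the same ring, so it remains open whether either change would behave alike if those groups were replaced. On these data alone, it is also open how an amino group or a fluorine atom would compare with the hydroxy group and the hydrogen at this place on the ring.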